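From 3-bromo-4-methylphenyl to pentyl on the shared core

A few compounds are considered here, and "the series" means these few. Any claim that something is new, unique, unknown or untested is made for them only; others in the source may bear on it.

Of the compounds shown here, three sharing one core have been tested in a functional assay on MCF7 cells (Homo sapiens) for antiproliferative activity, read by MTT assay; on this read-out lower numbers stand for stronger inhibition and higher numbers for weaker inhibition. Among the compounds with values here, there, compound 1 `CC1(C)CCc2c(ccc(C(=O)/C=C/c3ccc(OCc4cn(-c5ccc(Br)cc5)nn4)cc3)c2O)O1` reads "not active" (no number reported), and compound 2 `CC(=O)c1ccc(-n2cc(COc3ccc(/C=C/C(=O)c4ccc5c(c4O)CCC(C)(C)O5)cc3)nn2)cc1` gives 171000 nM, the only number so far. Compound 3 `Cc1ccc(-n2cc(COc3ccc(/C=C/C(=O)c4ccc5c(c4O)CCC(C)(C)O5)cc3)nn2)cc1Br` reads "not active" (no number reported), so it has no single number and, like compound 1, cannot be placed exactly on the scale. Compound 4 `CCCCCn1cc(COc2ccc(/C=C/C(=O)c3ccc4c(c3O)CCC(C)(C)O4)cc2)nn1` is the next structure, with pentyl in place of 3-bromo-4-methylphenyl on an aromatic nitrogen. Within the data shown here, no measured step guides the change, so only a modest gain in this assay is expected, reaching about the level of compound 2 at 171000 nM. A result without a number also remains possible. Compound 4 is estimated at 100000 nM, with an expected range from 25000 nM to 300000 nM.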

Compound 4, half-maximal inhibitory concentration: 191000 nM
Compound 4: middle estimate off by 1.9-fold (0.28 log units), on the low side, within the range that was stated.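

In this assay a ring is not required on this aromatic nitrogen for a number to be reported: compound 4, with pentyl, gives 191000 nM, while compound 3 reads "not active" (no number reported). With a 1.1-fold higher number from compound 2 to compound 4 (0.05 log units; within the scatter), pentyl and 4-acetylphenyl read alike, so this change of a phenyl group for a chain leaves the value where it was. Nothing measured accounts for these results. As far as these compounds go, whether a shorter chain, a benzyl group, or a chain ending in an amine or a carboxylic acid would give a clearly lower number in this assay stays open.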